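Mirror-Image Change at One Chain Stereocentre

This account rests on a few compounds, and the source may have more. Where it says the series, first, only, none or still open, it means among the compounds named here.

Compound 1 `O=C1c2c[n+]([O-])c3ccccc3c2C(=O)c2c1c1ccccc1n2Cc1cn(C[C@@H](O)CO)nn1` is known in a functional assay on SH-SY5Y cells (Homo sapiens) for cytotoxicity, read by MTT assay, with a stated time of 72 h (on this read-out higher numbers stand for weaker inhibition and lower numbers for stronger inhibition), only as a limit: compound 1 gives > 500 nM (the limit of > 500 nM in this assay, at which 1 of the 2 values shown sits). Compound 2 `CC1(C)OCC(Cn2cc(Cn3c4c(c5ccccc53)C(=O)c3c[n+]([O-])c5ccccc5c3C4=O)nn2)O1` gives 230 nM in this assay, and the step of an at least 2.1-fold lower number from compound 1 to compound 2 (0.33 log units; beyond the scatter) concerns a different change. Compound 3 `O=C1c2c[n+]([O-])c3ccccc3c2C(=O)c2c1c1ccccc1n2Cc1cn(C[C@H](O)CO)nn1` differs from compound 1 as follows: the two compounds have the same atoms and bonds and differ only in configuration as drawn: 1 of 1 stereo elements differ; a stereocentre at a saturated chain carbon is drawn R in compound 1 and S in compound 3. For the measured compounds named here, no measured step involves a change of configuration alone, so there is no measured basis for expecting a step beyond the scatter in this assay. Compound 3 is therefore expected near 600 nM (range 250 nM to 2000 nM), an expected step that the limit leaves unreadable from compound 1 to compound 3 that amounts to no real change.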

Compound 3, half-maximal inhibitory concentration: > 1000 nM
Compound 3 was reported as a limit; the forecaster's own chance of this, stated with the estimate: 60%; at least 1.6-fold (0.22 log units) between middle value and limit.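

In this assay compound 3 gives > 1000 nM, which is a limit of the assay. Compound 1 gives > 500 nM, also a limit, so the step between these two mirror-image compounds cannot be read. Setting 1,2-dihydroxyethyl with the S configuration in place of 2,2-dimethyl-1,3-dioxolan-4-yl gives an at least 4.3-fold higher number from compound 2 to compound 3 (0.63 log units; beyond the scatter), so this change now has a measured step for each drawn configuration of the diol, one of them only a bound.

Left open is whether the two configurations differ at all, and how an amine or a carboxylic acid on this chain would read in this assay.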